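Hydrogen in place of fluoro: what to expect

This account rests on a few compounds, and the source may have more. Where it says the series, first, only, none or still open, it means among the compounds named here.

Compound 1 `COc1ccc(S(=O)(=O)N2CCc3cccc(-c4ccc(F)nc4)c32)cc1`: 151 nM
Compound 2 `COc1ccc(S(=O)(=O)N2CCc3cccc(-c4ccc(N(C)C)cc4)c32)cc1`: 553 nM
Compound 3 `COc1ccc(S(=O)(=O)N2CCc3cccc(-c4ccc(F)cc4)c32)cc1`: 94.6 nM

These values come from a functional assay on KB-VIN10 cells (Homo sapiens) for inhibition, with a stated time of 72 h; a lower number here means a stronger inhibitor, a higher number a weaker inhibitor. Compound 3 cannot be told apart from one of the other two compounds, with a 1.6-fold lower number from compound 1 to compound 3 (0.20 log units; within the scatter). It is clearly separated from the other, with a 5.8-fold lower number from compound 2 to compound 3 (0.77 log units; beyond the scatter).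

The next structure is compound 4 `COc1ccc(S(=O)(=O)N2CCc3cccc(-c4ccccc4)c32)cc1`, and the change is hydrogen in place of fluoro on an aromatic carbon, para to a large group. Among the measured compounds shown here, no measured pair makes this exact change, so the evidence is indirect. Compound 2 shows that a change at this place can register, with a 5.8-fold lower number from compound 2 to compound 3 (0.77 log units; beyond the scatter), but that step exchanged dimethylamino and not hydrogen, and it is only modest. Compound 1 differs from compound 3 by a change of ring, and that step stays within the scatter. Together these suggest a small effect from losing one fluoro, with at most a slight drift towards a higher number in this assay. The expected change is a 1.3-fold higher number from compound 3 to compound 4 (0.10 log units; within the scatter), and no step beyond the scatter is expected. Compound 4 is estimated at 120 nM, with an expected range of 60 nM to 250 nM.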

Compound 4, half-maximal inhibitory concentration: 107 nM
The estimate for compound 4 lay 1.1-fold (0.05 log units) above the measured number; the measured number falls inside the stated range.
By their numbers in this assay, from the lowest: compounds 3, 4 and 1 (each within the scatter of the next); then compound 2.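

In this assay, among the compounds shown here, the fluoro para to a large group proves dispensable: hydrogen in its place gives a step within the scatter (a 1.1-fold higher number from compound 3 to compound 4 (0.05 log units; within the scatter)), the first direct reading of this change at this place. The phenyl of compound 4 also cannot be told apart from the 6-fluoropyridin-3-yl of compound 1 (a 1.4-fold lower number from compound 1 to compound 4 (0.15 log units; within the scatter)), so the fluoro on the carbocycle and the change of ring both leave the number within the scatter, and these three compounds have no order among them. Dimethylamino alone stands apart, and it does so against hydrogen (a 5.2-fold lower number from compound 2 to compound 4 (0.71 log units; beyond the scatter)) as well as against fluoro, so the separation of compound 2 does not depend on the fluoro of compound 3.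

For the compounds shown here, how this place responds to other kinds of group, such as a carboxylic acid, a primary amine or a longer alkoxy chain, remains open, since dimethylamino is the only group here that moves the number beyond the scatter. Nothing on hand explains why dimethylamino stands apart from hydrogen and fluoro.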